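The compounds below may be only part of what the source reports. "The series", "measured", "known", "first", "only" and "open" are said of these compounds alone.

Series notes. Compound 1 `Cc1ccc(-c2csc(N/N=C/c3ccc(Cl)cc3Cl)n2)cc1` and compound 2 `Clc1ccc(-c2csc(N/N=C/c3ccc(Cl)cc3Cl)n2)cc1` share one core and differ at a single aromatic carbon. In a functional assay, read by spectrophotometry, with a stated time of 15 min, tested at 80 ug/mL (a lower number here means a weaker effect, a higher number a stronger effect of the compound at the concentration tested), compound 1 gives 90.7%. In this assay compound 2 gives 92.3%. Among the compounds with values here, the only measured step in the set is a number 1.6 percentage points higher from compound 1 to compound 2 (within the scatter). On the two numbers shown, compound 2 stands at the top, yet its distance to compound 1 is within the scatter, so the two cannot be separated.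

Compound 3 `Clc1ccc(/C=N/Nc2nc(-c3ccccc3)cs2)c(Cl)c1` is not yet measured. It departs from compound 2 as hydrogen in place of chloro on an aromatic carbon. Within the data shown here, the single measured step bears on this because a number 1.6 percentage points higher from compound 1 to compound 2 (within the scatter) concerns the same aromatic carbon and shows that exchanging one group for another there left the read-out within the scatter. Among the measured compounds shown here, no measured step removes a group to hydrogen at that carbon, so the expectation for compound 3 rests on that one step alone. For compound 3 a step of a number 4.3 percentage points lower from compound 2 to compound 3 (within the scatter) is expected, within the scatter. Compound 3 is accordingly estimated at 88%, between 78% and 95%.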

Compound 3, a percentage reported as inhibition, at one concentration (the size of the read-out at that concentration, not a potency): 92.6%
Compound 3: the middle estimate sits 4.6 percentage points below what was measured; low and high end bracket the measured number.
By their numbers in this assay, from the lowest: compounds 1, 2 and 3 (each within the scatter of the next).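

With hydrogen in place of chloro on the aromatic carbon para to a large group, the read-out shows a number 0.3 percentage points higher from compound 2 to compound 3 (within the scatter) in this assay and with hydrogen in place of methyl at that same carbon it shows a number 1.9 percentage points higher from compound 1 to compound 3 (within the scatter) at the tested concentration. The earlier step covered only an exchange of one group for another, whereas these steps show that the 4-chlorophenyl and phenyl forms cannot be separated in this assay and that the substituent is not needed at this carbon for the read-out seen here. Nothing available on these compounds accounts for this flat result. From the compounds shown here alone, whether an amine, a carboxylic acid or a longer chain at this carbon would shift the read-out beyond the scatter remains open, as does the effect of changing the two chloro groups found in all three compounds. With every number taken at a single concentration, whether compound 1, compound 2 and compound 3 would differ in effect at any other concentration also remains unresolved.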